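Swapping the Aryl Group on a Weak Growth Inhibitor

This account rests on a few compounds, and the source may have more. Where it says the series, first, only, none or still open, it means among the compounds named here.

In a functional assay on MIA PaCa-2 cells (Homo sapiens) for inhibition, read by MTT assay, with a stated time of 48 h, tested at 10 uM (on this read-out lower numbers stand for less inhibition of growth and higher numbers for more inhibition of growth at the one concentration tested), compound 2 `Cc1oc2c([C@H]3CCN(C)C[C@H]3O)c(O)cc(O)c2c(=O)c1C(O)c1ccc(F)c(Br)c1` gives 9% and compound 1 `Cc1oc2c([C@H]3CCN(C)C[C@H]3O)c(O)cc(O)c2c(=O)c1C(O)c1ccc([N+](=O)[O-])cc1` gives 2%, two values within the scatter of each other. Neither number shows much effect on growth at the single concentration tested. Compound 3 `Cc1oc2c([C@H]3CCN(C)C[C@H]3O)c(O)cc(O)c2c(=O)c1C(O)c1c(F)cccc1Cl` keeps the shared core but carries 2-chloro-6-fluorophenyl in place of 3-bromo-4-fluorophenyl on a saturated chain carbon bound to an aromatic carbon and an oxygen on a saturated carbon. Among the measured compounds shown here, only one measured step bears on this place, and a number 7 percentage points higher from compound 1 to compound 2 (within the scatter) stayed within the scatter. For the measured compounds named here, a single step is thin evidence, and no measured compound carries the new group, so the range stays wide. The expected change is a number 2 percentage points higher from compound 2 to compound 3 (within the scatter), and no step beyond the scatter is expected. For compound 3 the estimated value is 11%, with an expected range of 0% to 30%.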

Compound 3, percent growth inhibition at one concentration: 41%
Compound 3: the middle estimate sits 30 percentage points below what was measured; measured number above the stated range.
By their numbers in this assay, from the lowest: compounds 1 and 2 (each within the scatter of the next); then compound 3.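

In this assay, among the compounds shown here, this position turns out to matter for growth inhibition: placing 2-chloro-6-fluorophenyl here gives a number 32 percentage points higher from compound 2 to compound 3 (beyond the scatter) and a number 39 percentage points higher from compound 1 to compound 3 (beyond the scatter), whereas the one earlier step stayed within the scatter. The groups that leave and enter in the step to compound 3 have the same heavy-atom, donor and acceptor counts, so those counts alone do not separate compound 2 from compound 3. Nothing available here accounts for the rise.

Compound 3 differs from compound 2 both in carrying chlorine rather than bromine and in where its halogens sit on the ring, so the effects of these two differences cannot be told apart. Going by these compounds, it also remains open how a plain phenyl group, or a phenyl group carrying an amine, would read at this position.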